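This account rests on a few compounds, and the source may have more. Where it says the series, first, only, none or still open, it means among the compounds named here.

The series in this account consists of two measured compounds and one that still awaits measurement, all judged in an assay on SH-SY5Y cells for inhibition of Voltage-dependent N-type calcium channel subunit alpha-1B (Homo sapiens), read by FLIPR and calcium flux, with stated times of 600 s and 300 s, in the presence of a further agent that is not named here; on this read-out lower numbers stand for stronger inhibition and higher numbers for weaker inhibition. Compound 1, `CN(Cc1ccc(OCCCN)cc1)c1nc2ccc(Oc3ccccc3)cc2s1`, gives in this assay a value of 49000 nM. Compound 2, `CN(C)CCCOc1ccc(CNc2nc3ccc(Oc4ccc(C#N)cc4)cc3s2)cc1`, gives in this assay a value of 105000 nM. Of these two numbers, compound 1 stands lowest, and its gap to compound 2 lies beyond the usual scatter, so compound 1 is the stronger inhibitor of the pair in this assay. Going by the values given here, no two measured compounds differ from one another in only one place, so there is no measured single step on which to lean.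

Compound 3, `CN(Cc1ccc(OCCCN)cc1)c1nc2ccc(Oc3ccc(C(F)(F)F)cc3)cc2s1`, is compound 1 with one alteration: trifluoromethyl in place of hydrogen on an aromatic carbon. Among the compounds with values here, the alteration sits on the phenoxy group that both compounds share, and the data offer no measured precedent for it. Without such a precedent, the account expects no step beyond the usual scatter, and the expected step of a 1.4-fold lower number from compound 1 to compound 3 (0.15 log units; within the scatter) is estimated to be small, leaning slightly toward a lower number. Compound 3 is therefore expected to give in this assay about 35000 nM, within a range from 12000 nM to 100000 nM.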

Compound 3, half-maximal inhibitory concentration: 283000 nM
Estimate against measurement, compound 3: 8.1-fold (0.91 log units) below; the whole stated range lies below it.
By their numbers in this assay, from the lowest: compound 1; then compound 2; then compound 3.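

The trifluoromethyl change gives this series its first measured single step: in this assay, placing the group on the aromatic carbon of the phenoxy group, para to a large group, produces a 5.8-fold higher number from compound 1 to compound 3 (0.76 log units; beyond the scatter) and so moves toward weaker inhibition. This shows that the position does not tolerate every substituent without consequence, since going from phenoxy to 4-(trifluoromethyl)phenoxy on the otherwise unchanged structure of compound 1 costs inhibition in this read-out. Nothing available bears on what lies behind this loss, so the step stands as an observation only.

Going by these compounds alone, the single step cannot show whether the loss belongs to trifluoromethyl alone or to any replacement of hydrogen at this carbon, so it remains open how a chlorine atom, a methoxy group or a carboxylic acid in the same place would read. Going by these compounds, it is also open whether the same change would have a comparable effect on a compound with a longer chain in place of the aminopropoxy chain of compound 1, or with a tertiary amine at its end.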